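Swapping the amide tail of a weakly toxic series

The source may hold more compounds than are shown below. What is called first, only, known or untested is meant among the compounds shown, and "the series" means these compounds.

Three compounds share one core and differ only in the basic amine tail hanging from an amide. Compound 1 `CC1=C(C(C)C(=O)NCCN2CCCC2)c2cc(F)ccc2/C1=C\c1ccc([S+](C)[O-])cc1` was tested in a functional assay on PC-3 cells (Homo sapiens) for inhibition, read by CellTiter-Glo, with a stated time of 72 h (on this read-out lower numbers stand for higher toxicity in this test and higher numbers for lower toxicity in this test), where compound 1 gives 32000 nM. Compound 2 `CC1=C(C(C)C(=O)NCCN2CCCCC2)c2cc(F)ccc2/C1=C\c1ccc([S+](C)[O-])cc1` carries a larger ring on the same tail, and in this assay compound 2 gives 36300 nM. Compound 3 `CC1=C(C(C)C(=O)NCCN2CCNCC2)c2cc(F)ccc2/C1=C\c1ccc([S+](C)[O-])cc1` has a piperazin-1-yl ring in that place. In this assay compound 3 reaches only a limit of the test, > 50000 nM, so no exact number is known for it. Compound 3 is the one that sits at the limit of > 50000 nM in this assay, at which 1 of the 3 values shown sits. The measured steps are all small: a 1.1-fold higher number from compound 1 to compound 2 (0.05 log units; within the scatter), an at least 1.5-fold higher number from compound 1 to compound 3 (0.19 log units; that floor lies within the scatter) and an at least 1.3-fold higher number from compound 2 to compound 3 (0.13 log units; that floor lies within the scatter). Changing the ring at the end of the tail therefore did not shift the read-out beyond the usual scatter in any of these three.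

Compound 4 `CC1=C(C(C)C(=O)N2CCN(CCCN(C)C)CC2)c2cc(F)ccc2/C1=C\c1ccc([S+](C)[O-])cc1` changes the tail more deeply: 4-(3-(dimethylamino)propyl)piperazin-1-yl in place of (2-(piperazin-1-yl)ethyl)amino on a carbonyl carbon. The measured steps touch only the ring at the end of the chain, not the amide itself, so they bear on this change only loosely, but they give no sign that any tail variation moves toxicity much. Compound 4 is therefore expected to show a step of an at least 1.1-fold lower number from compound 3 to compound 4 (0.04 log units; that floor lies within the scatter), which amounts to no change beyond the scatter. Compound 4 is estimated at 45000 nM, with a range from 20000 nM to 100000 nM.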

Compound 4, half-maximal cytotoxic concentration: > 50000 nM
Compound 4 gave a limit, no number; the forecaster's own chance of this, stated with the estimate: 40%; middle value at least 1.1-fold (0.04 log units) from the limit.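

For the compounds shown here, the new tail, 4-(3-(dimethylamino)propyl)piperazin-1-yl, alters the attachment on the carbonyl carbon itself and removes the hydrogen-bond donors of the old tail, a deeper change than the ring swaps among the earlier compounds, and in this assay compound 4 gives > 50000 nM, which is a limit of the test and not a number. Against the other two tails, the result reads as an at least 1.3-fold higher number from compound 2 to compound 4 (0.13 log units; that floor lies within the scatter) and as an at least 1.5-fold higher number from compound 1 to compound 4 (0.19 log units; that floor lies within the scatter), so even this larger change on the carbonyl carbon gives no step shown to lie beyond the scatter. Compound 3 and compound 4 now share the same limit, so the step between them cannot be read: the limit of > 50000 nM in this assay, at which 2 of the 4 values shown sit.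

The compounds shown leave open whether any group on this carbonyl carbon can take the read-out clearly away from these values, for example a tail ending in a carboxylic acid, a primary amine, or a longer chain carrying the dimethylamino group. They also leave open what exact numbers compound 3 and compound 4 would give, and so how these two compare.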